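Chain-end unsaturation and cytotoxicity toward a breast cancer line

A few compounds are considered here, and "the series" means these few. Any claim that something is new, unique, unknown or untested is made for them only; others in the source may bear on it.

Compound 1, `CCCCCn1c(Cc2cc(OC)c(OC)c(OC)c2)nc2c(N)nc(F)nc21`: 286000000 nM
Compound 2, `C=CCCCn1c(Cc2cc(OC)c(OC)c(OC)c2)nc2c(N)nc(F)nc21`: 55600000 nM

Of the compounds shown here, two have been measured in a functional assay on MCF7 cells (Homo sapiens) for cytotoxicity; a lower number here means that less compound is needed, a higher number that more compound is needed for the effect. Compound 1 gives 286000000 nM. Among the measured compounds shown here, compound 2 gives 55600000 nM, the lowest of the two numbers; the only step known is a 5.1-fold lower number from compound 1 to compound 2 (0.71 log units; beyond the scatter). Compound 3, `C#CCCn1c(Cc2cc(OC)c(OC)c(OC)c2)nc2c(N)nc(F)nc21`, has not yet been measured. It differs from compound 2 by ethynyl in place of allyl on a saturated chain carbon, two bonds along the chain from an aromatic nitrogen. For the measured compounds named here, the one measured step bears on this change only loosely, since it raised the unsaturation of the same chain without shortening it, whereas here the chain also loses one carbon. A further but smaller lowering of the number in this assay is therefore expected, with the chain shortening leaving the direction uncertain. Compound 3 is estimated at 25000000 nM, within 6000000 nM to 100000000 nM, which means an expected step of a 2.2-fold lower number from compound 2 to compound 3 (0.35 log units; beyond the scatter).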

Compound 3, half-maximal effective concentration: 286000000 nM
Compound 3: middle estimate off by 11-fold (1.06 log units), on the low side, and the stated range ends below it.
By their numbers in this assay, from the lowest: compound 2; then compounds 1 and 3 (each within the scatter of the next).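

Ethynyl in place of allyl, on a saturated chain carbon, two bonds along the chain from an aromatic nitrogen, gave a 5.1-fold higher number from compound 2 to compound 3 (0.71 log units; beyond the scatter) in this assay and so did not keep the lower number of compound 2. Ethynyl in place of propyl gave no change at the digits printed from compound 1 to compound 3 (within the scatter) in this assay, so unsaturation at the chain end does not go with a lower number across these compounds: compound 2 follows that pattern, while compound 3 goes against it. No available evidence bears on this result.

The compounds shown leave open whether the kind of unsaturation or the length of the chain accounts for the step between compound 2 and compound 3. Also open, going by these compounds, is how a pent-4-yn-1-yl chain, or a chain ending in an amine, would read in this assay on the shared core.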